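The source may report more compounds than this note shows. Statements on the series, on what has been measured and on what is new or still open speak of the compounds shown alone.

Working notes on the phenoxymethyl series.

Of the compounds shown here, three have numbers so far. Compound 1 `Cc1nn(Cc2cccc(C(=O)N(C)C)c2)c(C)c1NC(=O)c1ccc(COc2ccccc2)cc1` gives 6400 nM in a functional assay on MIA PaCa-2 cells (Homo sapiens) for antiproliferative activity, read by MTT assay, with a stated time of 72 h; on this read-out lower numbers stand for an effect already at smaller amounts and higher numbers for an effect only at larger amounts of compound. Compound 2 `CNC(=O)c1cccc(Cn2nc(C)c(NC(=O)c3ccc(COc4ccccc4C)cc3)c2C)c1` gives 2100 nM in this assay. Compound 3 `CNC(=O)c1cccc(Cn2nc(C)c(NC(=O)c3ccc(COc4cccc(C)c4)cc3)c2C)c1` gives 6200 nM in this assay. Within the data shown here, compound 3 stands second highest of the three numbers: its value and that of compound 1 lie within the scatter of each other, whereas the single one-place step recorded, a 3.0-fold higher number from compound 2 to compound 3 (0.47 log units; beyond the scatter), is beyond the scatter and shows compound 2 with the lowest number of the set.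

The next compound is compound 4 `CNC(=O)c1cccc(Cn2nc(C)c(NC(=O)c3ccc(COc4ccc(OC)cc4)cc3)c2C)c1`. It is reached from compound 3 by 4-methoxyphenyl in place of 3-methylphenyl on an oxygen on a saturated carbon. Among the measured compounds shown here, no measured step introduces a methoxy group anywhere on this phenoxy ring, so the only step with any bearing is a 3.0-fold higher number from compound 2 to compound 3 (0.47 log units; beyond the scatter), which shows that moving a small group around this ring can shift the number by a modest amount in either direction. With nothing pointing to a large shift, the expected step of a 1.2-fold lower number from compound 3 to compound 4 (0.09 log units; within the scatter) is estimated as small, most likely within the scatter, with a wide range to allow for a modest move either way. Compound 4 is therefore expected to give about 5000 nM in this assay, with an estimated range from 1800 nM to 14000 nM.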

Compound 4, half-maximal effective concentration: 8000 nM
For compound 4 the middle estimate is 1.6-fold (0.20 log units) below the measured one; the range from low to high includes it.
By their numbers in this assay, from the lowest: compound 2; then compounds 3, 1 and 4 (each within the scatter of the next).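

In this assay, the 4-methoxyphenyl group on this oxygen brings a hydrogen-bond acceptor to the ring, yet a 1.3-fold higher number from compound 3 to compound 4 (0.11 log units; within the scatter) leaves it within the scatter of the 3-methylphenyl group, so this exchange of groups gives no readable change. Against the 2-methylphenyl group the same new group does separate, with a 3.8-fold higher number from compound 2 to compound 4 (0.58 log units; beyond the scatter), so compound 2 now stands apart from two differently substituted rings, compound 3 and compound 4, and not from compound 3 alone. Among these three compounds, only the 2-methylphenyl group gives a lower number, while the 3-methylphenyl and 4-methoxyphenyl groups cannot be told apart; no measurement at hand speaks to the reason for these numbers.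

The compounds shown leave open whether the lower number of compound 2 is tied to the 2-methylphenyl group itself or would also hold for another group in its place, such as 2-methoxyphenyl or 2-chlorophenyl. Going by these compounds, it also remains open how the number would respond to an amine or a carboxylic acid on this ring.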